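This account rests on a few compounds, and the source may have more. Where it says the series, first, only, none or still open, it means among the compounds named here.

Working notes on the series. Compound 1 `Cc1nn(C)c(-n2cccn2)c1/C=N/OCc1ccc(C(=O)OC(C)(C)C)cc1` gives 5.51 ug/mL in a functional assay on XF498 cells (Homo sapiens) for cytotoxicity; a lower number here means a stronger inhibitor, a higher number a weaker inhibitor. Compound 2 `Cc1nn(C)c(-n2ccc3ccccc32)c1/C=N/OCc1ccc(C(=O)OC(C)(C)C)cc1` gives 1.61 ug/mL in this assay and stands lowest of the two numbers; the step of a 3.4-fold lower number from compound 1 to compound 2 (0.53 log units; beyond the scatter) is the only one measured. Compound 3 `Cc1nn(C)c(N(C)C)c1/C=N/OCc1ccc(C(=O)OC(C)(C)C)cc1` carries the change (dimethylamino in place of 1H-indol-1-yl on an aromatic carbon). That single step bears on it only loosely, since it shows that the group on this carbon moves the number by a modest amount, and here both rings of that group are lost. A rise beyond the scatter is therefore expected. Compound 3 is expected at 6 ug/mL (range 2.5 ug/mL to 15 ug/mL), an expected step of a 3.7-fold higher number from compound 2 to compound 3 (0.57 log units; beyond the scatter).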

Compound 3, half-maximal inhibitory concentration: 3.87 ug/mL
Compound 3: middle estimate off by 1.6-fold (0.19 log units), on the high side, within the range that was stated.
By their numbers in this assay, from the lowest: compound 2; then compounds 3 and 1 (each within the scatter of the next).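

In (this assay), dimethylamino on this carbon, which carries no ring, stands level with 1H-pyrazol-1-yl (a 1.4-fold lower number from compound 1 to compound 3 (0.15 log units; within the scatter)), so an aromatic ring on this carbon is not required to reach that level. Of the three groups, only 1H-indol-1-yl stands apart (a 2.4-fold higher number from compound 2 to compound 3 (0.38 log units; beyond the scatter)). Nothing at hand explains the gap between these groups. Open, as far as these compounds go, is whether the gain follows from the fused six-membered ring of 1H-indol-1-yl or from the total size of the group. Also open, from the compounds shown here alone, is how a saturated ring amine such as morpholine or a methoxy group would fare on this carbon.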